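This account rests on a few compounds, and the source may have more. Where it says the series, first, only, none or still open, it means among the compounds named here.

Compound 3 `CC(C(=O)NCc1ccc(C(C)(C)C)nc1N1CCCCCC1)c1ccc(NS(C)(=O)=O)c(F)c1` gives 0.9 nM in an assay on cells for antagonist activity at transient receptor potential cation channel subfamily V member 1 (Homo sapiens), read by FLIPR and calcium flux, with a stated time of 6 min (on this read-out lower numbers stand for stronger inhibition and higher numbers for weaker inhibition), the lowest of the three numbers, though its neighbours sit within the scatter: compound 1 `CCCCN(C)c1nc(C(C)(C)C)ccc1CNC(=O)C(C)c1ccc(NS(C)(=O)=O)c(F)c1` gives 1.2 nM and compound 2 `CC(C(=O)NCc1ccc(C(C)(C)C)nc1N1CCCC1)c1ccc(NS(C)(=O)=O)c(F)c1` gives 1.2 nM, with a 1.3-fold lower number from compound 1 to compound 3 (0.12 log units; within the scatter), a 1.3-fold lower number from compound 2 to compound 3 (0.12 log units; within the scatter) and no change at the digits printed from compound 1 to compound 2 (within the scatter). Compound 4 `CCOc1nc(C(C)(C)C)ccc1CNC(=O)C(C)c1ccc(NS(C)(=O)=O)c(F)c1` carries the change (ethoxy in place of azepan-1-yl on an aromatic carbon). Within the data shown here, the three measured steps bear on it only loosely: each swaps one amino group for another and each stays within the scatter, but none replaces the nitrogen-linked group by an oxygen-linked one, so no measured step speaks to this change directly. A modest rise in the number is therefore expected, a 2.8-fold higher number from compound 3 to compound 4 (0.44 log units; beyond the scatter), with wide uncertainty. Compound 4 is estimated at 2.5 nM, in the range 0.7 nM to 9 nM.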

Compound 4, inhibition constant: 14.8 nM
For compound 4 the middle estimate is 5.9-fold (0.77 log units) below the measured one, outside the stated range (above it).
By their numbers in this assay, from the lowest: compounds 3, 1 and 2 (each within the scatter of the next); then compound 4.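

In this assay, the three nitrogen-linked groups at this position stay within the scatter of one another, but ethoxy stands clearly apart from all of them, with a 16-fold higher number from compound 3 to compound 4 (1.22 log units; beyond the scatter), a 12-fold higher number from compound 2 to compound 4 (1.09 log units; beyond the scatter) and a 12-fold higher number from compound 1 to compound 4 (1.09 log units; beyond the scatter). The step is large whether the group leaving is a ring or an open chain, so it is not tied to azepan-1-yl alone. Nothing at hand explains this difference. Ethoxy differs from these groups in both its linking atom and its size, and the compounds shown do not separate the two. A butoxy group, or a small amine such as dimethylamino, would pull them apart.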